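The compounds below may be only part of what the source reports. "The series", "measured", "known", "first", "only" and "open" are said of these compounds alone.

Three compounds share one core and differ only in the group carried on an amine nitrogen in a ring. Compound 1 `COc1ccc(N2CCN(Cn3nc(C(C)c4ccc(CC(C)C)cc4)oc3=S)CC2)cc1` gives 42.6% in a functional assay on the whole organism (strain Wister albino) for inhibition, with Rattus norvegicus as the target, read by paw edema, with stated times of 30 min and 3 h, at a dose of 10 mg/kg by the oral route; on this read-out lower numbers stand for less inhibition and higher numbers for more inhibition at the one dose given (going by the name of the read-out). Compound 2 `CC(C)Cc1ccc(C(C)c2nn(CN3CCN(c4ccc(Cl)cc4)CC3)c(=S)o2)cc1` gives 76.6%, and compound 3 `CC(C)Cc1ccc(C(C)c2nn(CN3CCN(c4ccc([N+](=O)[O-])cc4)CC3)c(=S)o2)cc1` gives 75.1%. Compound 3 therefore stands second highest of the three, close to compound 2 and far above compound 1: the step of a number 1.5 percentage points lower from compound 2 to compound 3 (within the scatter) is within the scatter, while a number 32.5 percentage points higher from compound 1 to compound 3 (beyond the scatter) and a number 34 percentage points higher from compound 1 to compound 2 (beyond the scatter) are both large.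

Compound 4 `CCOc1ccccc1N1CCN(Cn2nc(C(C)c3ccc(CC(C)C)cc3)oc2=S)CC1` is not yet measured. Relative to compound 3 the change is 2-ethoxyphenyl in place of 4-nitrophenyl on an amine nitrogen in a ring. The measured steps that bear on this are a number 34 percentage points higher from compound 1 to compound 2 (beyond the scatter) and a number 32.5 percentage points higher from compound 1 to compound 3 (beyond the scatter), which show that the methoxy-bearing compound 1 sits well below the chloro and nitro compounds. Within the data shown here, compound 4 again carries an alkoxy group, an ethoxy, though at a different place on its phenyl, so no measured pair matches it exactly. A sizeable drop is expected from compound 3, estimated as a number 23.1 percentage points lower from compound 3 to compound 4 (beyond the scatter), landing between compound 1 and compound 3. Compound 4 is thus expected to give about 52%, within a range of 35% to 70%.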

Compound 4, a percentage reported as inhibition, in the whole organism at one dose (the size of the read-out at that dose, not a potency): 44.6%
Compound 4: middle estimate off by 7.4 percentage points, on the high side; the measured number falls inside the stated range.
By their numbers in this assay, from the lowest: compounds 1 and 4 (each within the scatter of the next); then compounds 3 and 2 (each within the scatter of the next).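

Placing 2-ethoxyphenyl on the ring amine nitrogen brings a large loss in this assay: the change is a number 30.5 percentage points lower from compound 3 to compound 4 (beyond the scatter) and a number 32 percentage points lower from compound 2 to compound 4 (beyond the scatter), whereas a number 2 percentage points higher from compound 1 to compound 4 (within the scatter) stays small. The low level seen with 4-methoxyphenyl is therefore not unique to that group, since a phenyl carrying a different alkoxy group at a different ring position gives a value within the scatter of it. Among these four compounds, the two alkoxy-bearing phenyls sit low and 4-chlorophenyl and 4-nitrophenyl sit high, but nothing available here accounts for this split.

Because 2-ethoxyphenyl differs from 4-methoxyphenyl in both the alkoxy group and its position, the two effects cannot be separated here. A 4-ethoxyphenyl or 2-chlorophenyl group would pull them apart, and an unsubstituted phenyl would provide a baseline for all four.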